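Swapping a methoxy for a chloro on the aryl ring

The compounds below may be only part of what the source reports. "The series", "measured", "known", "first", "only" and "open" are said of these compounds alone.

Of the compounds shown here, two of one shared core have been measured in a functional assay on A549 cells (Homo sapiens) for antiproliferative activity, read by MTT assay, with a stated time of 72 h; on this read-out lower numbers stand for stronger inhibition and higher numbers for weaker inhibition. Compound 1, `COc1ccc(N2C(=O)COc3ccc(-c4cnc(OC)c(NS(=O)(=O)c5ccc(F)cc5)c4)cc32)cc1`, gives 1350 nM and so stands at the lowest number of the two. Compound 2, `O=C1COc2ccc(-c3cnc(Cl)c(NS(=O)(=O)c4ccc(F)cc4)c3)cc2N1c1ccccc1`, gives 14700 nM in this assay, a much higher number that lies beyond the scatter; compound 2 differs from compound 1 in more than one place, so its gap cannot be tied to a single change.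

Compound 3, `COc1ncc(-c2ccc3c(c2)N(c2ccc(Cl)cc2)C(=O)CO3)cc1NS(=O)(=O)c1ccc(F)cc1`, differs from compound 1 in one place only: chloro in place of methoxy on an aromatic carbon. The whole change sits on the aromatic ring that carries no nitrogen, para to a large group, and reads as 4-methoxyphenyl becoming 4-chlorophenyl.

Among the compounds with values here, no measured pair here shows this exact exchange, so nothing in the data fixes its size or direction. The expectation is therefore a small step of a 1.1-fold higher number from compound 1 to compound 3 (0.05 log units; within the scatter) in this assay, none beyond the scatter. On that basis compound 3 is estimated at 1500 nM, with a range from 500 nM to 5000 nM.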

Compound 3, half-maximal inhibitory concentration: 8350 nM
Beside the measured number, compound 3's estimate is 5.6-fold (0.75 log units) below it; measured number outside the range, above it.
By their numbers in this assay, from the lowest: compound 1; then compounds 3 and 2 (each within the scatter of the next).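

Within the data shown here, compound 1 and compound 3 form the first pair in this set that differs in one place only, so a single change can now be read on its own. In this assay the exchange of 4-methoxyphenyl for 4-chlorophenyl gives a 6.2-fold higher number from compound 1 to compound 3 (0.79 log units; beyond the scatter) and lies beyond the usual scatter, which shows that the group on this aromatic carbon, para to a large group, matters to the read-out and that chloro here goes with weaker inhibition than methoxy. Nothing among the available measurements explains why the number rises on this exchange.

This single pair cannot show whether the step is particular to chloro or whether other groups at this place would behave in the same way, and a methyl, a hydroxyl or an amine on this ring would help to settle that. It also leaves open whether the same exchange would give a step of similar size and direction on a compound that differs elsewhere in the shared core, since one pair defines no trend.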